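The source may hold more compounds than are shown below. What is called first, only, known or untested is meant among the compounds shown, and "the series" means these compounds.

Measured compounds:
Compound 1, `COc1cc(-n2cnc3ccc(-c4ccc(C(F)(F)F)cc4)cc32)cc(OC)c1OC`, in a functional assay on SGC-7901 cells (Homo sapiens) for antiproliferative activity, read by MTT assay, with a stated time of 72 h (on this read-out lower numbers stand for stronger inhibition and higher numbers for weaker inhibition), compound 1 gives 890 nM.
Compound 2, `COc1cc(-n2cnc3ccc(-c4ccc(Cl)cc4)cc32)cc(OC)c1OC`, in this assay compound 2 gives 1270 nM.
Compound 3, `COc1cc(-n2cnc3ccc(-c4ccc(C)cc4F)cc32)cc(OC)c1OC`, in this assay compound 3 gives 5650 nM.

Compound 2 stands second highest of the three numbers, next to compound 1 by a gap that stays within the scatter, and well apart from compound 3. The unmeasured compound 4, `COc1cc(-n2cnc3ccc(-c4cccc(O)c4)cc32)cc(OC)c1OC`, differs from compound 2 in one place: 3-hydroxyphenyl in place of 4-chlorophenyl on an aromatic carbon. For the measured compounds named here, two measured steps touch this position. The step of a 1.4-fold higher number from compound 1 to compound 2 (0.15 log units; within the scatter) shows that exchanging one group for another on the same aromatic carbon can leave the number unchanged within the scatter, while the step of a 4.4-fold higher number from compound 2 to compound 3 (0.65 log units; beyond the scatter) shows that a group with a different substitution pattern raised the number by a modest amount. Going by the values given here, the entering 3-hydroxyphenyl again carries its single substituent in a different pattern from the 4-chlorophenyl that leaves, and it brings a hydrogen-bond donor and acceptor that none of the measured compounds has, so a modest rise in the number is the more likely outcome, with the chance that it stays within the scatter. Compound 4 is therefore expected to show a step of a 2.4-fold higher number from compound 2 to compound 4 (0.37 log units; beyond the scatter), giving an estimated 3000 nM, within a range from 1000 nM to 9000 nM.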

Compound 4, half-maximal inhibitory concentration: 53 nM
Estimate against measurement, compound 4: 57-fold (1.75 log units) above; measured number outside the range, below it.
By their numbers in this assay, from the lowest: compound 4; then compounds 1 and 2 (each within the scatter of the next); then compound 3.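

In this assay, for the compounds shown here, this aromatic carbon proves far more responsive than the earlier compounds suggested, with 3-hydroxyphenyl in place of 4-chlorophenyl giving a 24-fold lower number from compound 2 to compound 4 (1.38 log units; beyond the scatter) and the same group giving a 17-fold lower number from compound 1 to compound 4 (1.23 log units; beyond the scatter) as well as a 110-fold lower number from compound 3 to compound 4 (2.03 log units; beyond the scatter). Compound 4 thus stands as the most potent of the four, and a change of aryl group here can lower the number sharply, whereas the earlier changes either stayed within the scatter or raised it. Nothing shown gives a reason for this gain or separates the part played by the hydroxyl group from that of its place on the ring.

Open, from the compounds shown here alone, is whether 4-hydroxyphenyl would give a number close to that of compound 4. Also open, going by these compounds, is whether 3-aminophenyl or 3-methoxyphenyl would keep such a low number.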